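This account rests on a few compounds, and the source may have more. Where it says the series, first, only, none or still open, it means among the compounds named here.

Measured so far in a functional assay on 1321-N1 cells for agonist activity at P2Y purinoceptor 6 (Homo sapiens), read by scintillation counting and inositol phosphate accumulation; on this read-out lower numbers stand for an effect already at smaller amounts and higher numbers for an effect only at larger amounts of compound:
compound 1 `O=c1[nH]/c(=N\OCCCc2cccc(F)c2)ccn1[C@@H]1O[C@H](COP(=O)(O)OP(=O)(O)OP(=O)(O)O)[C@@H](O)[C@H]1O`: 539 nM
compound 2 `O=c1[nH]/c(=N\OCCCc2cccc(I)c2)ccn1[C@@H]1O[C@H](COP(=O)(O)OP(=O)(O)OP(=O)(O)O)[C@@H](O)[C@H]1O`: 299 nM

Compound 2 shows the lower of these two numbers, yet a 1.8-fold lower number from compound 1 to compound 2 (0.26 log units; within the scatter) lies within the scatter, so no real order between compound 1 and compound 2 is established. Compound 3 `O=c1[nH]/c(=N\OCCCc2cccc([N+](=O)[O-])c2)ccn1[C@@H]1O[C@H](COP(=O)(O)OP(=O)(O)OP(=O)(O)O)[C@@H](O)[C@H]1O` differs from compound 2 by nitro in place of iodo on an aromatic carbon. Going by the values given here, the only measured step exchanges one halogen for another, and a nitro group is not a halogen, so no measured step speaks directly to this change. The expectation is therefore a step of a 1.3-fold higher number from compound 2 to compound 3 (0.13 log units; within the scatter) in this assay, not clearly beyond the scatter in either direction. Compound 3 is estimated at 400 nM, with a range from 150 nM to 1200 nM.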

Compound 3, half-maximal effective concentration: 9700 nM
Compound 3: the middle estimate sits 24-fold (1.38 log units) below what was measured; measured number above the stated range.
By their numbers in this assay, from the lowest: compounds 2 and 1 (each within the scatter of the next); then compound 3.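

The group on this aromatic carbon clearly matters in this assay: swapping in nitro gives a 32-fold higher number from compound 2 to compound 3 (1.51 log units; beyond the scatter) and also an 18-fold higher number from compound 1 to compound 3 (1.26 log units; beyond the scatter), both steps well beyond the scatter. The similar numbers for fluoro and iodo therefore do not extend to every group placed here. Nothing available explains this large rise. From the compounds shown here alone, whether an amine, a methoxy group or a carboxylic acid on this carbon would match the halogens or nitro remains open, as does whether nitro would give a similar step on another ring carbon.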